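A few compounds are considered here, and "the series" means these few. Any claim that something is new, unique, unknown or untested is made for them only; others in the source may bear on it.

Measured compounds:
- compound 1 `CC/C=C/[C@H](CC)C/C(=C/[C@@]1(CC)C[C@H](CC)[C@H](CC(=O)O)OO1)CC`: "not determined" (no result reported) in a functional assay on HL-60 cells (Homo sapiens) for cytotoxicity; a higher number here means a weaker inhibitor, a lower number a stronger inhibitor
- compound 2 `CC/C=C/[C@H](CC)C[C@]1(CC)C=C(CC)/C(=C/C(=O)OC)O1`: 8.6 ug/mL

Within the data shown here, compound 2 supplies the only number. In this assay compound 2 gives 8.6 ug/mL. In this assay, among the measured compounds shown here, compound 1 gives "not determined" (no result reported), so no step between measured compounds can be stated, and no comparison of compound 1 with compound 2 is possible on the data at hand.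

Compound 3 `CC/C=C/[C@H](CC)C[C@]1(C)C=C(CC)/C(=C/C(=O)OC)O1` is the next entry to be run in this assay. It differs from compound 2 in one place: hydrogen in place of methyl on a saturated chain carbon bound to a saturated ring carbon. The same difference, cut one bond further out, reads ethyl to methyl; the core is otherwise unchanged.

For the measured compounds named here, with no measured step to lean on, the expectation for this change rests on its small size alone. The step from compound 2 to compound 3 is expected to be a 1.2-fold higher number from compound 2 to compound 3 (0.07 log units; within the scatter), that is, nothing beyond the scatter in either direction. Compound 3 is accordingly estimated at 10 ug/mL, within a range of 4 ug/mL to 25 ug/mL.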

Compound 3, half-maximal inhibitory concentration: > 25 ug/mL
Compound 3: only a limit was reported; the forecaster's own chance of this, stated with the estimate: 10%; middle value at least 2.5-fold (0.39 log units) from the limit.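

In this assay, the change from ethyl to methyl gives an at least 2.9-fold higher number from compound 2 to compound 3 (0.46 log units; beyond the scatter), so this position responds to the removal of one carbon from the chain. Among these compounds, this is the first step that can be read, since compound 2 previously stood alone as the only number, and it places ethyl ahead of methyl here by more than the scatter. For compound 3, the reported value of > 25 ug/mL is a limit and not a number, so the step gives only a lower bound on the size of the change: the limit of > 25 ug/mL in this assay, at which 1 of the 3 values shown sits.

Only ethyl and methyl are shown at this place, so the trend has two points and one of them is open-ended; whether a propyl group or a longer chain would lower the number further, hold it level or raise it remains unknown. Also open, going by these compounds, is how a polar group at the end of this chain, such as an amine or a carboxylic acid, would compare with ethyl in this assay on the otherwise unchanged core.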